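The source may hold more compounds than are shown below. What is called first, only, known or untested is meant among the compounds shown, and "the series" means these compounds.

Measured compounds: compound 1 `CC[C@@H]1C(=O)N(C)c2cnc(-n3ccc4cc(C(N)=O)ccc43)nc2N1C1CCCC1` gives 28.5 nM in an assay for inhibition of serine/threonine-protein kinase PLK2 (Homo sapiens), read by FRET and Z'-LYTE, with a stated time of 1 h; a lower number here means a stronger inhibitor, a higher number a weaker inhibitor; compound 2 `CC[C@@H]1C(=O)N(C)c2cnc(-n3ccc4cc(C(=O)NC5CCCC5)ccc43)nc2N1C1CCCC1` gives 7.06 nM; compound 3 `CCC1C(=O)N(C)c2cnc(-n3ccc4cc(C(=O)NC5CCCC5)ccc43)nc2N1c1ccn(C)n1` gives 90.9 nM.

Compounds 1 and 2 share one core, compound 3 carries another; the difference between the two cores is not broken down here. Within the first core, the change hydrogen in place of cyclopentyl on an amide-type nitrogen gave a 4.0-fold higher number from compound 2 to compound 1 (0.61 log units; beyond the scatter). Compound 4 `CCC1C(=O)N(C)c2cnc(-n3ccc4cc(C(N)=O)ccc43)nc2N1c1ccn(C)n1` has not been measured; it differs from compound 3 by hydrogen in place of cyclopentyl on an amide-type nitrogen, the same change made on the second core. The expectation for compound 4 rests on that single earlier step, with compound 3 at 90.9 nM as the starting point, and it is estimated as a 3.9-fold higher number from compound 3 to compound 4 (0.59 log units; beyond the scatter). The estimate for compound 4 in this assay is therefore 350 nM, expected to lie between 150 nM and 900 nM.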

Compound 4, half-maximal inhibitory concentration: 384 nM
Beside the measured number, compound 4's estimate is 1.1-fold (0.04 log units) below it; low and high end bracket the measured number.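

On the second core, hydrogen in place of cyclopentyl on an amide-type nitrogen gives a 4.2-fold higher number from compound 3 to compound 4 (0.63 log units; beyond the scatter) in this assay. The step therefore carries over from the first core with its size intact: the same change on two cores in this assay, a 4.0-fold higher number (0.61 log units; beyond the scatter) from compound 2 to compound 1 and a 4.2-fold higher number (0.63 log units; beyond the scatter) from compound 3 to compound 4, 1.0-fold (0.02 log units) apart, within the scatter of two such steps This rests on one pair of compounds per core, so it does not show that the change would behave the same way on any other core, and it does not explain why the step has this size.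

The compounds shown leave open how a methyl group or an open chain such as isopropyl on that nitrogen would compare with hydrogen and cyclopentyl. They also leave open whether a cyclopentyl carrying an amine or a carboxylic acid would keep the same step.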